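A Group Swap Starting From an Assay Limit

A few compounds are considered here, and "the series" means these few. Any claim that something is new, unique, unknown or untested is made for them only; others in the source may bear on it.

Compound 1 `O=C(Nc1ccc(Br)cc1)Nc1nc(-c2cc3ccccc3o2)cs1`: > 200000 nM
Compound 2 `COc1ccc(NC(=O)Nc2nc(-c3cc4cc(Br)ccc4o3)cs2)cc1`: > 200000 nM

In a physicochemical assay, with a stated time of 6 min (on this read-out higher numbers stand for weaker inhibition and lower numbers for stronger inhibition), compound 1 gives > 200000 nM. That value is a limit, not a number. Compound 2 gives > 200000 nM, which is also a limit. The whole picture so far is the limit of > 200000 nM in this assay, at which 2 of the 2 values shown sit.

Compound 3 `O=C(Nc1nc(-c2cc3ccccc3o2)cs1)Nc1ccccc1[N+](=O)[O-]` has not yet been measured. It keeps the core of compound 1 but has 2-nitrophenyl in place of 4-bromophenyl on an amide-type nitrogen.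

Among the compounds with values here, no measured pair shows what a change of this kind does. For compound 3, no shift beyond the scatter is expected in this assay, in either direction, since compound 1 stands at > 200000 nM, itself a limit. The estimated change is a number no higher from compound 1 to compound 3 (the limit leaves the size open). The expected value for compound 3 is 200000 nM, with an estimated range from 60000 nM to 400000 nM.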

Compound 3, half-maximal inhibitory concentration: 20300 nM
Beside the measured number, compound 3's estimate is 9.9-fold (0.99 log units) above it, outside the stated range (below it).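

In this assay, the group on the amide-type nitrogen turns out to matter: 2-nitrophenyl in place of 4-bromophenyl gives an at least 9.8-fold lower number from compound 1 to compound 3 (0.99 log units; beyond the scatter). Within the data shown here, compound 3 is the first compound here with a real number rather than a limit, so this position can move the read-out, something compound 1 and compound 2 could not show on their own. Even so, the limit remains the most common result: the limit of > 200000 nM in this assay, at which 2 of the 3 values shown sit.

This single swap removes the bromine and brings in the nitro group at once, and it leaves open which of the two changes accounts for the step. As far as these compounds go, how a plain phenyl, or a phenyl carrying an amine or a carboxylic acid, would read on this nitrogen also remains open.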